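Forced swim inhibition in a coumarin–chromene series

The source may report more compounds than this note shows. Statements on the series, on what has been measured and on what is new or still open speak of the compounds shown alone.

Measured compounds and their values:
Compound 1, `COc1ccc(-c2cc3cc(C4C(C#N)=C(N)OC5=C4C(=O)CC(C)(C)C5)cc(C)c3oc2=O)cc1OC`: 10.4%
Compound 2, `COc1cc(-c2cc3cc(C4C(C#N)=C(N)OC5=C4C(=O)CC(C)(C)C5)cc(C)c3oc2=O)cc(OC)c1OC`: 6.37%
Compound 3, `COc1ccc(-c2cc3cc(C4C(C#N)=C(N)OC5=C4C(=O)CCC5)cc(C(C)C)c3oc2=O)cc1OC`: 57.2%

In a functional assay on the whole organism (strain Swiss albino) with Mus musculus as the target, in the forced swim test, with a stated time of 5 min, at a dose of 0.5 mg/kg by the intraperitoneal route (a lower number here means less inhibition, a higher number more inhibition at the dose given (going by the name of the read-out)), compound 1 gives 10.4% and compound 2 gives 6.37%. The two differ by methoxy in place of hydrogen on an aromatic carbon, and the step of a number 4 percentage points lower from compound 1 to compound 2 (within the scatter). Compound 3, built on a different core, gives 57.2% in this assay, the highest of the three; the difference between its core and that of compound 1 is not broken down here.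

Compound 4, `COc1cc(-c2cc3cc(C4C(C#N)=C(N)OC5=C4C(=O)CCC5)cc(C(C)C)c3oc2=O)cc(OC)c1OC`, has not been measured. It differs from compound 3 by methoxy in place of hydrogen on an aromatic carbon, the same change already seen from compound 1 to compound 2. Because the step of a number 4 percentage points lower from compound 1 to compound 2 (within the scatter), compound 4 is expected to stay close to compound 3 in this assay, with an expected step of a number 4.2 percentage points lower from compound 3 to compound 4 (within the scatter). The estimate for compound 4 is 53%, between 35% and 70%.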

Compound 4, a percentage reported as inhibition, in the whole organism at one dose (the size of the read-out at that dose, not a potency): 31.9%
Compound 4: the middle estimate sits 21.1 percentage points above what was measured; measured number below the stated range.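

In this assay, the change from 3,4-dimethoxyphenyl to 3,4,5-trimethoxyphenyl did not carry over unchanged from one core to the other, giving a number 25.3 percentage points lower from compound 3 to compound 4 (beyond the scatter). Set beside the earlier step, the two do differ: the same change on two cores in this assay, a number 4 percentage points lower (within the scatter) from compound 1 to compound 2 and a number 25.3 percentage points lower (beyond the scatter) from compound 3 to compound 4, 21.3 percentage points apart, beyond the scatter of two such steps. This shows that the size of the step was not the same on these two cores, but two pairs cannot show which feature of the cores accounts for that, or how the change would behave on a further core.

The compounds shown leave open whether a hydroxyl, an amine or a longer chain such as ethoxy in place of the added methoxy would follow the same course. They also leave open what the isopropyl group of compound 3 contributes on its own, apart from the other differences between the cores.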